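The compounds below may be only part of what the source reports. "The series", "measured", "known", "first", "only" and "open" are said of these compounds alone.

Compound 1 `C/C=C/C(=O)N(Cc1ccc(OC)c(N)c1)c1cc(OC)c(OC)c(OC)c1`: 310 nM
Compound 2 `C/C=C/C(=O)N(Cc1ccc(OC)c(Br)c1)c1cc(OC)c(OC)c(OC)c1`: 10500 nM

In a functional assay on KYSE-450 cells (Homo sapiens) for inhibition, read by MTT assay, with a stated time of 48 h (a lower number here means a stronger inhibitor, a higher number a weaker inhibitor), compound 2 stands highest of the two at 10500 nM and so is the weaker inhibitor. Compound 3 `C/C=C/C(=O)N(Cc1ccc(OC)c(C)c1)c1cc(OC)c(OC)c(OC)c1` has methyl in place of bromo on an aromatic carbon, a change counted as methyl in place of bromo on an aromatic carbon in full. Going by the values given here, the only measured step at this place is a 34-fold higher number from compound 1 to compound 2 (1.53 log units; beyond the scatter) and it is large, but it concerns amino and bromo and shows nothing directly about methyl. Without the amino group, no full return to the level of compound 1 at 310 nM is expected. A modest move to a lower number is expected, namely a 2.3-fold lower number from compound 2 to compound 3 (0.37 log units; beyond the scatter) as a rough guess. For compound 3 the estimate is 4500 nM with an expected range from 1000 nM to 15000 nM in this assay.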

Compound 3, half-maximal inhibitory concentration: 32900 nM
Estimate against measurement, compound 3: 7.3-fold (0.86 log units) below; measured number outside the range, above it.
By their numbers in this assay, from the lowest: compound 1; then compound 2; then compound 3.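

In this assay, methyl in place of bromo gives a 3.1-fold higher number from compound 2 to compound 3 (0.50 log units; beyond the scatter), so bromo was not the poorest group at this position, and the change of a single heavy atom still moves the number beyond the scatter. Methyl in place of amino gives a 110-fold higher number from compound 1 to compound 3 (2.03 log units; beyond the scatter), the widest gap among these three compounds, which sets amino further apart from the other two groups. Nothing measured here accounts for this order. As far as these compounds go, whether a hydroxyl, a methylamino or a dimethylamino group at this position would match amino remains open.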